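Aryl swap on the shared core, compound 3 to compound 4

The compounds below may be only part of what the source reports. "The series", "measured", "known", "first", "only" and "open" are said of these compounds alone.

Three compounds share one core and differ only in the aryl group on a carbon with a double bond to nitrogen. In a functional assay on HT-29 cells (Homo sapiens) for cytotoxicity, read by MTT assay, with a stated time of 48 h, tested at 12.5 uM (a higher number here means a stronger effect of the compound at the concentration tested, a lower number a weaker effect), compound 1 `CS(=O)(=O)c1ccc(Cc2nnc3n2N=C(c2ccc(-c4ccccc4)cc2)CS3)cc1` gives 58.2%. Compound 2 `CS(=O)(=O)c1ccc(Cc2nnc3n2N=C(c2cc(Cl)sc2Cl)CS3)cc1` is reported in this assay as "not active" (no number reported), with no number. Compound 3 `CS(=O)(=O)c1ccc(Cc2nnc3n2N=C(c2ccc(Cl)cc2Cl)CS3)cc1` gives 28% in this assay, the lowest of the two numbers; compound 1 lies higher by a difference beyond the scatter. Compound 4 `Cc1ccc(C2=Nn3c(Cc4ccc(S(C)(=O)=O)cc4)nnc3SC2)cc1` is not yet measured and differs from compound 3 in one place: 4-methylphenyl in place of 2,4-dichlorophenyl on a carbon with a double bond to nitrogen. For the measured compounds named here, no measured step covers this change, so the expectation rests on the spread among the three aryl variants. The step of a number 8 percentage points higher from compound 3 to compound 4 (within the scatter) is expected to be modest and upward, with wide uncertainty. For compound 4 the estimated value is 36%, with a range from 12% to 60%.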

Compound 4, a percentage reported as activity, at one concentration (the size of the read-out at that concentration, not a potency): "not active" (no number reported)
Nothing numeric was reported for compound 4, and the estimate cannot be compared.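

For the compounds shown here, compound 4 carries no number, and no step from compound 3 to compound 4 can be read. The compounds shown leave open how 4-methylphenyl compares with 2,4-dichlorophenyl on the shared core, and no evidence bears on this result.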